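Cyano in place of methoxy: tolerance notes

The source may hold more compounds than are shown below. What is called first, only, known or untested is meant among the compounds shown, and "the series" means these compounds.

Compound 2 `COc1ccc(Nc2cc(Oc3c(C)cccc3C)c([N+](=O)[O-])cc2[N+](=O)[O-])cc1` stands in an ADME assay on H9 cells (Homo sapiens) for cytotoxicity, read by XTT assay, with a stated time of 6 days (a higher number here means that more compound is tolerated, a lower number that less compound is tolerated), only as a limit (> 61100 nM). Compound 1 `Cc1cc(C#N)cc(C)c1Oc1cc(Nc2ccc(C#N)cc2)c([N+](=O)[O-])cc1[N+](=O)[O-]`, which also carries the 4-cyanophenyl group, likewise shows only a limit (> 58200 nM). Compound 3 `Cc1cccc(C)c1Oc1cc(Nc2ccc(C#N)cc2)c([N+](=O)[O-])cc1[N+](=O)[O-]` differs from compound 2 at one place, with cyano in place of methoxy on an aromatic carbon, para to a large group (cyano in place of methoxy on an aromatic carbon). For the measured compounds named here, no measured step exists yet. No change beyond the usual scatter is expected in this assay in either direction, and the estimated at least 1.0-fold lower number from compound 2 to compound 3 (0.00 log units; that floor lies within the scatter) is small. For compound 3 the expected half-maximal cytotoxic concentration is 60000 nM, with an estimated range of 25000 nM to 65000 nM.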

Compound 3, half-maximal cytotoxic concentration: > 61800 nM
Compound 3 was reported as a limit (the forecaster's own chance of this, stated with the estimate: 75%); middle value at least 1.0-fold (0.01 log units) from the limit.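

For the compounds shown here, compound 1, compound 2 and compound 3 all stand only as limits in this assay; no step among them can be read. From the compounds shown here alone, the concentration at which any of the three stops being tolerated, and any effect of cyano in place of methoxy, stays open.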